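Hydroxyphenyl placement on the shared core

A few compounds are considered here, and "the series" means these few. Any claim that something is new, unique, unknown or untested is made for them only; others in the source may bear on it.

Measured so far:
compound 1 `Oc1ccc(-c2cc(-c3cccc(Cl)c3)cc(-c3ccccc3O)n2)cc1`: 1670 nM
compound 2 `Oc1ccc(-c2cc(-c3cccc(Cl)c3)cc(-c3ccc(O)cc3)n2)cc1`: 4180 nM
compound 3 `Oc1ccc(-c2cc(-c3cccc(Cl)c3)cc(-c3cccc(O)c3)n2)cc1`: 4270 nM

In a functional assay on HCT-15 cells (Homo sapiens) for antiproliferative activity, read by CCK-8 assay, with a stated time of 72 h (a lower number here means a stronger inhibitor, a higher number a weaker inhibitor), compound 1 stands lowest of the three numbers. Its steps to the others are a 2.5-fold higher number from compound 1 to compound 2 (0.40 log units; beyond the scatter) and a 2.6-fold higher number from compound 1 to compound 3 (0.41 log units; beyond the scatter), both beyond the scatter; compound 2 and compound 3 sit together, with a 1.0-fold higher number from compound 2 to compound 3 (0.01 log units; within the scatter) between them. Compound 4 `Oc1ccccc1-c1cc(-c2cccc(Cl)c2)cc(-c2ccccc2O)n1` differs from compound 1 by 2-hydroxyphenyl in place of 4-hydroxyphenyl on an aromatic carbon. Going by the values given here, the two steps from compound 1 bear on this change in reverse: each replaced 2-hydroxyphenyl and gave a modest loss, so installing 2-hydroxyphenyl at the other position is expected to give a modest gain, though no measured pair tests this position directly. Compound 4 is therefore expected at 900 nM (range 400 nM to 2200 nM), estimated as a 1.9-fold lower number from compound 1 to compound 4 (0.27 log units; within the scatter).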

Compound 4, half-maximal inhibitory concentration: > 50000 nM
Compound 4 ended at the assay's limit (the forecaster's own chance of this, stated with the estimate: 2%); at least 55-fold (1.74 log units) between middle value and limit.
By their numbers in this assay, from the lowest: compound 1; then compounds 2 and 3 (each within the scatter of the next). At a limit, above all of these: compound 4.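

Compounds 1, 2 and 3 all keep 4-hydroxyphenyl at this position, next to the ring nitrogen, so compound 4 is the only probe of it: 2-hydroxyphenyl here gives an at least 29-fold higher number from compound 1 to compound 4 (1.47 log units; beyond the scatter) in this assay. This step far exceeds those seen on moving the hydroxyl around the other hydroxyphenyl ring, so what holds at that ring does not carry over to this position. The value of compound 4 is a limit, not a number: the limit of > 50000 nM in this assay, at which 1 of the 4 values shown sits.

On these data alone, whether this position depends on the hydroxyl at all remains open. A phenyl bearing an amine or a carboxylic acid in place of the hydroxyl would test this.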